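This account rests on a few compounds, and the source may have more. Where it says the series, first, only, none or still open, it means among the compounds named here.

Measured compounds:
Compound 1 `Cc1cc(Nc2cc(-c3ccccc3)[nH]n2)n2nc(SCc3cccc(Br)c3)nc2n1`, which in a functional assay on MCF7 cells (Homo sapiens) for inhibition, read by MTT assay, with a stated time of 72 h (a higher number here means a weaker inhibitor, a lower number a stronger inhibitor), gives 5140 nM.
Compound 2 `Cc1cc(Nc2ccn(Cc3ccc(F)cc3)n2)n2nc(SCc3ccc(Br)cc3)nc2n1`, which gives 4280 nM.
Compound 3 `COc1ccc(CSc2nc3nc(C)cc(Nc4cc(-c5ccccc5)[nH]n4)n3n2)cc1`, which gives 4020 nM.

Compound 1 has the highest number of the three, but its gaps to compound 2 and to compound 3 both lie within the scatter, so no order among them can be read. Compound 4 `Cc1cc(Nc2cc(-c3ccccc3)[nH]n2)n2nc(SCc3csc4ccccc34)nc2n1` differs from compound 1 in one place: 1-benzothiophen-3-yl in place of 3-bromophenyl on a saturated chain carbon bound to a sulfur. Within the data shown here, the only measured step at this same place is a 1.3-fold lower number from compound 1 to compound 3 (0.11 log units; within the scatter), which stayed within the scatter. Among the measured compounds shown here, that step is the one that bears on compound 4; a swap of the aryl group here has so far made no clear difference. A step of a 1.0-fold lower number from compound 1 to compound 4 (0.01 log units; within the scatter) is therefore expected, with no change beyond the scatter. Compound 4 is estimated at 5000 nM, between 2000 nM and 12500 nM.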

Compound 4, half-maximal inhibitory concentration: 3470 nM
Estimate against measurement, compound 4: 1.4-fold (0.16 log units) above, and the stated range covers the measured number.
By their numbers in this assay, from the lowest: compounds 4, 3, 2 and 1 (each within the scatter of the next).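

At this place, on a saturated chain carbon bound to a sulfur, a larger group with a five-membered and a six-membered aromatic ring still leaves the reading in this assay unchanged: 1-benzothiophen-3-yl gives a 1.5-fold lower number from compound 1 to compound 4 (0.17 log units; within the scatter) and a 1.2-fold lower number from compound 3 to compound 4 (0.06 log units; within the scatter). The three aryl groups on this carbon therefore cannot be ordered, even with a second ring added. No measurement bears on the reason for this result. As far as these compounds go, whether an amine, a carboxylic acid or a longer chain here would move the number beyond the scatter stays open.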